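The compounds below may be only part of what the source reports. "The series", "measured", "known", "first", "only" and "open" are said of these compounds alone.

Measured compounds:
Compound 1, `CS(=O)(=O)c1cc(C(=O)N=C(N)N)ccc1-n1cccn1` — in a functional assay for inhibition of sodium/hydrogen exchanger (Oryctolagus cuniculus) (on this read-out higher numbers stand for weaker inhibition and lower numbers for stronger inhibition), compound 1 gives 160 nM.
Compound 2, `CS(=O)(=O)c1cc(C(=O)N=C(N)N)ccc1-n1ccnc1` — in this assay compound 2 gives 150 nM.

Compound 2 carries the lowest of the two numbers, but its nearest neighbour, compound 1, sits within the usual scatter of it, so the two cannot be ranked. Within the data shown here, the only measured step, a 1.1-fold lower number from compound 1 to compound 2 (0.03 log units; within the scatter), exchanges one five-membered ring for another and produces no shift beyond the scatter.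

Compound 3, `CS(=O)(=O)c1cc(C(=O)N=C(N)N)ccc1C#N`, is not yet measured. It differs from compound 2 by cyano in place of 1H-imidazol-1-yl on an aromatic carbon. Among the measured compounds shown here, no measured step touches this kind of change: the one step in hand swaps two aromatic rings of similar size, whereas here the ring is removed altogether and a cyano group, a much smaller group, takes its place. The measured step therefore offers little guidance, and the expectation for compound 3 rests mainly on the shared core, which both compound 1 and compound 2 hold at a similar level.

For compound 3 in this assay, a value near 200 nM is estimated, with a wide range from 60 nM to 700 nM, corresponding to an expected step of a 1.3-fold higher number from compound 2 to compound 3 (0.12 log units; within the scatter).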

Compound 3, half-maximal inhibitory concentration: 140 nM
Compound 3: middle estimate off by 1.4-fold (0.15 log units), on the high side, and the stated range covers the measured number.
By their numbers in this assay, from the lowest: compounds 3, 2 and 1 (each within the scatter of the next).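

In this assay, cyano in place of 1H-imidazol-1-yl on the aromatic carbon ortho to a methylsulfonyl group gives a 1.1-fold lower number from compound 2 to compound 3 (0.03 log units; within the scatter) and cyano in place of 1H-pyrazol-1-yl gives a 1.1-fold lower number from compound 1 to compound 3 (0.06 log units; within the scatter). The earlier compounds showed only that one five-membered aromatic ring can stand in for another at this position, whereas these two steps show that the ring can give way to a much smaller group with no ring and the number still shows no shift beyond the scatter; among these three compounds, then, neither the ring nor its size separates the results. Nothing available explains why the three numbers stay so close together.

On these data alone, all three compounds carry either a five-membered aromatic ring or cyano at this position, so it remains open what a plain hydrogen, an amine, a carboxylic acid or a longer alkyl chain would do there. As far as these compounds go, it is also open whether this insensitivity would persist if the methylsulfonyl group were replaced by another group, such as a chlorine atom.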